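The source may hold more compounds than are shown below. What is called first, only, known or untested is meant among the compounds shown, and "the series" means these compounds.

Going by the values given here, compound 2 `CC(=O)N[C@@H]1CCC[C@H](C(=O)Nc2cc(-c3cnn4c3NCCC4)c(Cl)cn2)C1` holds the lower of the two numbers measured so far: in an ADME assay on cells (Hepatocyte, Rattus norvegicus) for metabolic stability, using equilibrium dialysis (on this read-out lower numbers stand for slow clearance and higher numbers for fast clearance), compound 2 gives 10 uL/min, whereas compound 1 `CC(=O)N[C@@H]1CCC[C@H](C(=O)Nc2cc(-c3cnn4c3CCC4)c(Cl)cn2)C1` gives 72 uL/min. Among the compounds with values here, the single measured step, a 7.2-fold lower number from compound 1 to compound 2 (0.86 log units; beyond the scatter), is the only comparison available. Compound 3 `CC(=O)N[C@@H]1CCC[C@H](C(=O)Nc2cc(-c3cnc4n3CC(C)(C)C4)c(Cl)cn2)C1` remains to be measured. a group of 10 heavy atoms (8 carbon, 2 nitrogen; one five-membered non-aromatic ring with 1 hetero atom, one five-membered aromatic ring with 2 hetero atoms) in place of a group of 9 heavy atoms (6 carbon, 3 nitrogen; one five-membered aromatic ring with 2 hetero atoms, one six-membered non-aromatic ring with 2 hetero atoms), on an aromatic carbon The group that enters shares with the group found in compound 1 a five-membered non-aromatic ring with 1 hetero atom and carries 0 hydrogen-bond donors, so the measured step bears on this change when read in reverse; that step was modest and beyond the scatter. The number for compound 3 is therefore expected to rise in this assay, with the step of a 4.5-fold higher number from compound 2 to compound 3 (0.65 log units; beyond the scatter) expected to be somewhat smaller than the one already seen. Compound 3 is estimated at 45 uL/min, within the range 18 uL/min to 110 uL/min.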

Compound 3, intrinsic clearance in a liver preparation (reported as CLH), per the amount of preparation that the assay uses in the Hepatocyte assay: 28 uL/min
The estimate for compound 3 lay 1.6-fold (0.21 log units) above the measured number, within the range that was stated.
By their numbers in the Hepatocyte assay, from the lowest: compound 2; then compound 3; then compound 1.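

In the Hepatocyte assay the position opposite the ring nitrogen now shows a third level, with compound 3 lying between the other two (a 2.6-fold lower number from compound 1 to compound 3 (0.41 log units; beyond the scatter)) and (a 2.8-fold higher number from compound 2 to compound 3 (0.45 log units; beyond the scatter)). Compound 1 and compound 3 both carry a five-membered non-aromatic ring with 1 hetero atom, yet their numbers differ beyond the scatter, so that ring type alone does not fix the clearance number. In a physicochemical assay for solubility, in phosphate buffer, at pH 7.4 (a lower number here means a less soluble compound, a higher number a more soluble compound), compound 2 gives 860000 nM and compound 3 gives 280000 nM in the same exchange of groups (a 3.1-fold lower number from compound 2 to compound 3 (0.49 log units; beyond the scatter)), so in this pair the higher clearance number comes with the lower solubility number.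

The compounds shown leave open how the Hepatocyte assay and the physicochemical assay would read for a hydroxyl group or a primary amine on the group at this position. With a single pair, any link between the two read-outs remains one observation.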